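The source may hold more compounds than are shown below. What is called first, only, known or untested is meant among the compounds shown, and "the series" means these compounds.

Working notes on the series. Compound 1 `C=C1C[C@]23C[C@@]1(O)CC[C@H]2c1cc(Br)c(O)c(C)c1[C@@H]3Cn1cc(-c2ccc(OC)cc2)nn1`, compound 2 `C=C1C[C@]23C[C@@]1(O)CC[C@H]2c1ccc(O)c(C)c1[C@@H]3Cn1cc(-c2ccc(F)cc2)nn1` and the not yet measured compound 3 `C=C1C[C@]23C[C@@]1(O)CC[C@H]2c1ccc(O)c(C)c1[C@@H]3Cn1cc(-c2ccc(OC)cc2)nn1` share one core and differ in the outer aryl group and, for compound 1, in the bromo on the core.

In a functional assay on SW480 cells (Homo sapiens) for cytotoxicity, read by MTT assay, with a stated time of 4 days (on this read-out higher numbers stand for weaker inhibition and lower numbers for stronger inhibition), compound 1 gives > 20000 nM, which is a limit of the assay and not a number. In this assay compound 2 likewise gives > 20000 nM, again a limit. Going by the values given here, compound 2 therefore stands at the limit, and the one further value shown is a limit as well: the limit of > 20000 nM in this assay, at which 2 of the 2 values shown sit. Among the compounds with values here, no step between two measured compounds carries a number, so nothing measured can be set beside the change to compound 3.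

That change is methoxy in place of fluoro on an aromatic carbon, in words methoxy in place of fluoro on an aromatic carbon. With both measured values at the limit, no direction can be read from the series. The step that the limit leaves unreadable from compound 2 to compound 3 is expected to stay within the scatter. Compound 3 is accordingly estimated at 30000 nM in this assay, with a range from 12000 nM to 100000 nM, most likely again reported only as a limit.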

Compound 3, half-maximal inhibitory concentration: > 20000 nM
Compound 3: no number, only a limit; the forecaster's own chance of this, stated with the estimate: 80%; the middle value is on the limit's open side.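

In this assay compound 3 gives > 20000 nM, a limit and not a number. The steps to compound 3 from compound 1 and from compound 2 therefore cannot be read, and the series yields no new step: the limit of > 20000 nM in this assay, at which 3 of the 3 values shown sit.

Going by these compounds, whether the outer aryl group or the bromo on the core affects the potency in this assay remains open.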